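The compounds below may be only part of what the source reports. "The series", "measured", "known", "first", "only" and "open" are said of these compounds alone.

Measured in a functional assay on Shh Light II cells (Mus musculus) for inhibition, read by a luciferase reporter; on this read-out lower numbers stand for stronger inhibition and higher numbers for weaker inhibition:
compound 1 `COc1ccccc1NC(=O)N1CCC(c2nc(-c3ccc4ccccc4n3)no2)CC1`: 410 nM
compound 2 `O=C(CC1CCCCCC1)N1CCC(c2nc(-c3ccc4ccccc4n3)no2)CC1`: 840 nM
compound 3 `O=C(NCC1CCC1)N1CCC(c2nc(-c3ccc4ccccc4n3)no2)CC1`: 410 nM

Compound 2 stands at the highest of the three numbers in this assay. Its two neighbours lie at the same distance: a 2.0-fold higher number from compound 1 to compound 2 (0.31 log units; beyond the scatter) and a 2.0-fold lower number from compound 2 to compound 3 (0.31 log units; beyond the scatter), each beyond the scatter. Compound 1 and compound 3 themselves show no change at the digits printed from compound 1 to compound 3 (within the scatter), so the two urea-type compounds sit together and the acyl compound 2 sits apart.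

Compound 4 `O=C(NC1CCOCC1)N1CCC(c2nc(-c3ccc4ccccc4n3)no2)CC1` differs from compound 2 in one place: (oxan-4-yl)amino in place of cycloheptylmethyl on a carbonyl carbon. The measured step that bears on this is a 2.0-fold lower number from compound 2 to compound 3 (0.31 log units; beyond the scatter), where likewise a ring-bearing amino group entered on the carbonyl carbon in place of cycloheptylmethyl. The step of no change at the digits printed from compound 1 to compound 3 (within the scatter) adds that, among these compounds, exchanging what sits on the amide-type nitrogen (2-methoxyphenyl for cyclobutylmethyl) left the number unchanged. Among the measured compounds shown here, on that basis the step into compound 4 is expected to resemble the one into compound 3, a modest move to a lower number: a 2.0-fold lower number from compound 2 to compound 4 (0.30 log units; within the scatter) is estimated. Compound 4 is therefore expected to give about 420 nM in this assay, with a range of 170 nM to 1100 nM.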

Compound 4, half-maximal inhibitory concentration: 480 nM
For compound 4 the middle estimate is 1.1-fold (0.06 log units) below the measured one; the range from low to high includes it.
By their numbers in this assay, from the lowest: compounds 1, 3, 4 and 2 (each within the scatter of the next, the first and the last beyond it).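

In this assay, oxan-4-yl on the amide-type nitrogen adds a third kind of group to this position, a six-membered ring with one hetero atom, and the number stays within the scatter of both earlier groups: a 1.2-fold higher number from compound 3 to compound 4 (0.07 log units; within the scatter) and a 1.2-fold higher number from compound 1 to compound 4 (0.07 log units; within the scatter). Cyclobutylmethyl, 2-methoxyphenyl and oxan-4-yl therefore cannot be told apart here, which extends what compound 1 and compound 3 showed to a group that carries a ring oxygen. On the carbonyl carbon, the exchange of cycloheptylmethyl for (oxan-4-yl)amino gives a 1.8-fold lower number from compound 2 to compound 4 (0.24 log units; within the scatter), so compound 2 no longer sits cleanly apart from every urea-type compound, although its steps to compound 1 and compound 3 are printed as beyond the scatter.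

No measurement at hand accounts for any of these steps. Open, on these data alone, is whether the amide hydrogen or the ring oxygen carries any weight in the step from compound 2, which an oxan-4-ylmethyl group on the carbonyl carbon would separate, and whether the flat response holds for a carboxylic acid or a primary amine on the ring, or for a longer chain.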